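The source may hold more compounds than are shown below. What is called first, only, known or untested is meant among the compounds shown, and "the series" means these compounds.

Measured in a functional assay on the whole organism (artery, strain albino) with Rattus norvegicus as the target, with a stated time of 900 min, at a dose of 10 mg/kg by the oral route; a higher number here means more inhibition at the dose given (going by the name of the read-out), a lower number less inhibition:

compound 1 `COc1ccc(C2N=C(SCc3ccc(Cl)cc3)NC(C)=C2C(=O)Nc2ccc(Br)cc2)cc1` gives 20%
compound 2 `COc1ccc(C2N=C(SCc3ccc(F)cc3)NC(C)=C2C(=O)Nc2ccc(Br)cc2)cc1` gives 15.4%
compound 3 `CC1=C(C(=O)Nc2ccc([N+](=O)[O-])cc2)C(c2ccc(Br)cc2)N=C(SCc2ccc(Cl)cc2)N1` gives 19%

Compounds 1 and 2 share one core and differ in a single place: fluoro in place of chloro on an aromatic carbon. The step in this assay is a number 4.6 percentage points lower from compound 1 to compound 2 (within the scatter), so the two numbers cannot be told apart.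

Compound 3 carries a different core; the difference between the two cores is not broken down here. Its number in this assay lies close to those of compound 1 and compound 2, and all three sit within the scatter of one another.

Compound 4 `CC1=C(C(=O)Nc2ccc([N+](=O)[O-])cc2)C(c2ccc(Br)cc2)N=C(SCc2ccc(F)cc2)N1` is not yet measured. It stands to compound 3 as compound 2 stands to compound 1: fluoro in place of chloro on an aromatic carbon. The place is described in the same words for both pairs, so this is the same change, made twice in the set.

For compound 4 the expected step is a number 4 percentage points lower from compound 3 to compound 4 (within the scatter), which rests on the measured step of a number 4.6 percentage points lower from compound 1 to compound 2 (within the scatter), itself within the scatter. Compound 4 is therefore estimated at 15%, with a likely range from 5% to 26%.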

Compound 4, a percentage reported as inhibition, in the whole organism at one dose (the size of the read-out at that dose, not a potency): 22.6%
For compound 4 the middle estimate is 7.6 percentage points below the measured one; measured number inside the range.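

In this assay, going from 4-chlorobenzyl to 4-fluorobenzyl gives a number 3.6 percentage points higher from compound 3 to compound 4 (within the scatter), so the chloro and fluoro members of this pair cannot be told apart. The comparison across the two cores gives no separable result either: the same change on two cores in this assay, a number 4.6 percentage points lower (within the scatter) from compound 1 to compound 2 and a number 3.6 percentage points higher (within the scatter) from compound 3 to compound 4, 8.2 percentage points apart, within the scatter of two such steps. At this single oral dose, the change therefore has no readable effect on either core, but this does not show that it carries from one core to the other with a fixed size or direction, nor that the two cores respond to it differently.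

The four compounds shown leave open what happens when the 4-chlorobenzyl or 4-fluorobenzyl group on sulfur gives way to a different kind of group, such as a longer alkyl chain or a benzyl group bearing an amine or a carboxylic acid. They also leave open whether the same halogen change would give a readable step in a compound with a higher number in this assay.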